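The source may report more compounds than this note shows. Statements on the series, on what has been measured and on what is new or still open speak of the compounds shown alone.

Three compounds that share one core and differ only in the group on a sulfur have been tested in a functional assay on MCF7 cells (Homo sapiens) for inhibition, read by MTT assay, with a stated time of 72 h; a lower number here means a stronger inhibitor, a higher number a weaker inhibitor. Compound 1 `Cc1csc(Sc2cc(C(F)(F)F)nc(SCc3ccc(C(F)(F)F)cc3)n2)n1` gives 14500 nM, compound 2 `FC(F)(F)c1ccc(CSc2nc(Sc3nncs3)cc(C(F)(F)F)n2)cc1` gives 8810 nM, and compound 3 `FC(F)(F)c1ccc(CSc2nc(SC3=NCCS3)cc(C(F)(F)F)n2)cc1` gives 44900 nM, the highest number of the three. Compound 4 `FC(F)(F)c1ccc(CSc2nc(Sc3ncc(-c4ccncc4)s3)cc(C(F)(F)F)n2)cc1` differs from compound 3 by one change: a group of 11 heavy atoms (8 carbon, 2 nitrogen, 1 sulfur; one five-membered aromatic ring with 2 hetero atoms, one six-membered aromatic ring with 1 hetero atom) in place of a group of 5 heavy atoms (3 carbon, 1 nitrogen, 1 sulfur; one five-membered non-aromatic ring with 2 hetero atoms), on a sulfur.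

Among the compounds with values here, three measured steps bear on this change. The exchange of one aromatic group for the other gave a 1.6-fold lower number from compound 1 to compound 2 (0.22 log units; within the scatter). Replacing an aromatic group with the non-aromatic ring gave a 3.1-fold higher number from compound 1 to compound 3 (0.49 log units; beyond the scatter) and a 5.1-fold higher number from compound 2 to compound 3 (0.71 log units; beyond the scatter). Compound 4 carries a five-membered aromatic ring again, so a modest step of similar size towards a lower number is expected in this assay, going by those last two steps. Within the data shown here, no measured compound has a six-membered aromatic ring in this group, so the range stays wide. The expected step is a 4.1-fold lower number from compound 3 to compound 4 (0.61 log units; beyond the scatter). The estimate for compound 4 is 11000 nM, with an expected range of 3500 nM to 35000 nM.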

Compound 4, half-maximal inhibitory concentration: 10100 nM
The estimate for compound 4 lay 1.1-fold (0.04 log units) above the measured number; measured number inside the range.
By their numbers in this assay, from the lowest: compounds 2, 4 and 1 (each within the scatter of the next); then compound 3.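

In this assay, the 5-(pyridin-4-yl)-1,3-thiazol-2-yl group on this sulfur shows that a much larger aromatic group can replace the non-aromatic ring with a gain, a 4.4-fold lower number from compound 3 to compound 4 (0.65 log units; beyond the scatter). Its added six-membered aromatic ring brings no readable change against the two smaller aromatic groups, with a 1.1-fold higher number from compound 2 to compound 4 (0.06 log units; within the scatter) and a 1.4-fold lower number from compound 1 to compound 4 (0.16 log units; within the scatter), so among these four compounds only compound 3 stands apart. No measured evidence here accounts for this.

With compound 3 as the only non-aromatic example, the compounds shown cannot separate the role of aromaticity from the other differences between these groups. They also leave open whether an amine or a carboxylic acid on the six-membered aromatic ring, or an open alkyl chain on this sulfur, would move the number beyond the scatter.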